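The compounds below may be only part of what the source reports. "The series", "measured", "known", "first", "only" and "open" are said of these compounds alone.

Measured compounds:
Compound 1 `CC(C)(C)c1ccc(NC(=O)c2cc(=O)[nH]c3cc(Br)ccc23)cc1` gives > 20000 nM in a functional assay on KYSE-410 cells (Homo sapiens) for antiproliferative activity, read by MTT assay, with a stated time of 72 h; a lower number here means a stronger inhibitor, a higher number a weaker inhibitor.
Compound 2 `O=C(Nc1cccc(F)c1)c1cc(=O)[nH]c2cc(-c3ccccc3)ccc12` gives > 20000 nM in this assay.

The value of compound 1 is a limit of the assay, not a number. The value of compound 2 is likewise a limit of the assay. For the measured compounds named here, compound 2 therefore stands at the limit of > 20000 nM in this assay, at which 2 of the 2 values shown sit, alongside the only other value, and the two compounds cannot be ordered against each other.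

Compound 3 `O=C(Nc1cccc(F)c1)c1cc(=O)[nH]c2cc(-c3ccc(F)nc3)ccc12` differs from compound 2 by 6-fluoropyridin-3-yl in place of phenyl on an aromatic carbon, on an aromatic carbon that is part of a fused system of two rings, meta to a fused ring and para to a fused ring. Going by the values given here, no step between measured compounds exists to guide the size of this change. With both known values sitting at the limit, the step expected in this assay is a number no higher from compound 2 to compound 3 (the limit leaves the size open), none beyond the usual scatter. Compound 3 is accordingly expected to give 20000 nM, between 8000 nM and 50000 nM, most likely reported again only as a limit.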

Compound 3, half-maximal inhibitory concentration: > 20000 nM
Compound 3: no number, only a limit (the forecaster's own chance of this, stated with the estimate: 70%); the middle value sits exactly at the limit.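

For the compounds shown here, compound 2 and compound 3 each give only a limit of the assay, so no step between them can be read. The compounds shown leave open whether 6-fluoropyridin-3-yl in place of phenyl makes any difference in this assay, and how the three compounds rank.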